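A Bromo Group in Place of an Aryl Group

The source may hold more compounds than are shown below. What is called first, only, known or untested is meant among the compounds shown, and "the series" means these compounds.

Of the compounds shown here, two sharing one core have been measured in an assay on HEK293 cells for inhibition of acid ceramidase (Homo sapiens), with a stated time of 10 min; on this read-out lower numbers stand for stronger inhibition and higher numbers for weaker inhibition. Compound 1 `O=C(NCCCCc1ccccc1)n1c(=O)oc2ccc(-c3ccccc3)cc21` gives 42 nM in this assay. Compound 2 `COc1ccc(-c2ccc3c(c2)oc(=O)n3C(=O)NCCCCc2ccccc2)cc1` gives 67 nM in this assay; its only neighbour on the numbers shown is compound 1, and the two values lie within the usual scatter of each other, so they show no difference beyond it. Compound 3 `O=C(NCCCCc1ccccc1)n1c(=O)oc2cc(Br)ccc21` has not yet been measured. It differs from compound 2 in one place: bromo in place of 4-methoxyphenyl on an aromatic carbon, a bromo in place of 4-methoxyphenyl on an aromatic carbon of the fused system, meta to a fused ring and para to a fused ring. Among the compounds with values here, no step between measured compounds is at hand to guide this change. The step from compound 2 to compound 3 is expected to be a modest rise in this assay, a 2.2-fold higher number from compound 2 to compound 3 (0.35 log units; beyond the scatter). Compound 3 is therefore estimated at 150 nM, with a range from 40 nM to 600 nM.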

Compound 3, half-maximal inhibitory concentration: 31 nM
Compound 3: the middle estimate sits 4.8-fold (0.68 log units) above what was measured; measured number below the stated range.
By their numbers in this assay, from the lowest: compounds 3, 1 and 2 (each within the scatter of the next, the first and the last beyond it).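

Both earlier compounds carry an aryl group on the shared core, so they could not show whether an aromatic ring is needed at all. In this assay, exchanging the 4-methoxyphenyl for bromo on this aromatic carbon removes that ring and leaves a single atom in place of eight, and the result is a 2.2-fold lower number from compound 2 to compound 3 (0.33 log units; beyond the scatter) and no loss of inhibition. The data give no reason for this gain, and nothing measured on these compounds bears on its cause.

As far as these compounds go, it remains open whether this position needs any substituent beyond hydrogen, and how a chloro, a methoxy or an amine on the same carbon would compare with bromo. From the compounds shown here alone, it is also open whether the same exchange would give a similar step with a different chain on the core.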